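Methoxy removal and tolerated concentration across four compounds

This account rests on a few compounds, and the source may have more. Where it says the series, first, only, none or still open, it means among the compounds named here.

The series is followed in an ADME assay on MT4 cells (Homo sapiens) for cytotoxicity, read by MTT assay, with a stated time of 4 days; a lower number here means that less compound is tolerated, a higher number that more compound is tolerated. Compound 1 `O=C(COc1cccc2ccccc12)N/N=C/c1cccc(O)c1` gives 32.6 ug/mL, compound 2 `COc1ccc(/C=N/NC(=O)COc2cccc3ccccc23)cc1O` gives 7.05 ug/mL, and compound 3 `COc1cc(/C=N/NC(=O)COc2cccc3ccccc23)cc(OC)c1OC` gives 13.4 ug/mL. The difference between the cores of compound 2 and compound 3 is not broken down here. Compound 4 `COc1ccc(/C=N/NC(=O)COc2cccc3ccccc23)cc1OC` has not yet been measured in this assay.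

Among the measured compounds shown here, the one counted step runs from compound 2 to compound 1: hydrogen in place of methoxy on an aromatic carbon gave a 4.6-fold higher number from compound 2 to compound 1 (0.67 log units; beyond the scatter). The same kind of change carries compound 3 to compound 4: hydrogen in place of methoxy on an aromatic carbon. The surroundings are not the same: in the first step the leaving methoxy sits ortho to a hydroxy group and para to a large group, whereas in the second it sits ortho to a methoxy group, meta to a large group and meta to a methoxy group. Compound 3 lies within the scatter of compound 2, and its gap to compound 1 is beyond the scatter.

For compound 4 a rise is expected, a 1.5-fold higher number from compound 3 to compound 4 (0.17 log units; within the scatter), kept smaller than the earlier step because a 4.6-fold higher number from compound 2 to compound 1 (0.67 log units; beyond the scatter) comes from a different setting around the place. Compound 4 is expected near 20 ug/mL, within a range from 8 ug/mL to 50 ug/mL.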

Compound 4, half-maximal cytotoxic concentration in the MT4 assay: 14.7 ug/mL
Compound 4: middle estimate off by 1.4-fold (0.13 log units), on the high side; measured number inside the range.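

In the MT4 assay compound 4 gives 14.7 ug/mL, and hydrogen in place of methoxy does not carry over from one core to the other with the same size: the same change on two cores in the MT4 assay, a 4.6-fold higher number (0.67 log units; beyond the scatter) from compound 2 to compound 1 and a 1.1-fold higher number (0.04 log units; within the scatter) from compound 3 to compound 4, 4.2-fold (0.62 log units) apart, beyond the scatter of two such steps

In the MT4 assay the new step, a 1.1-fold higher number from compound 3 to compound 4 (0.04 log units; within the scatter), gives no separation, whereas methyl in place of hydrogen on the oxygen gives a modest one, a 2.1-fold higher number from compound 2 to compound 4 (0.32 log units; beyond the scatter); in a physicochemical assay for lipophilicity, measured as octanol-water partition (a lower number here means a more polar compound, a higher number a more lipophilic compound), compound 3 gives 3.26 and compound 4 gives 3.51, and the step of a number 0.25 log units higher from compound 3 to compound 4 (within the scatter) also gives no separation. These two pairs show that the size of this change depends on its surroundings in this series, but they do not show which feature of those surroundings matters, and they give no rule for predicting the step on a further core.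

The aromatic ring carries only hydroxy and methoxy groups across the compounds shown, so the result of an amine or a carboxylic acid at the same place in the MT4 assay remains open. As far as these compounds go, the other end of the molecule is the same in all four compounds, so the effect of a change there also remains open.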